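Adding a Second Fluorine to an Inactive Scaffold

A few compounds are considered here, and "the series" means these few. Any claim that something is new, unique, unknown or untested is made for them only; others in the source may bear on it.

Compound 2 `Fc1ccc2nc(-c3ccccc3)nc(Nc3ccccc3)c2c1` and compound 1 `Fc1cccc(-c2nc(Nc3ccccc3)c3ccccc3n2)c1` share the same core. In a functional assay on HT29-AK cells (Homo sapiens) for cytotoxicity, read by MTT assay, with a stated time of 48 h (on this read-out higher numbers stand for weaker inhibition and lower numbers for stronger inhibition), compound 2 gives > 50000 nM, a limit of the assay rather than a number. In this assay compound 1 likewise gives > 50000 nM, also a limit. Both values sit at the limit of > 50000 nM in this assay, at which 2 of the 2 values shown sit. Compound 3 `Fc1cccc(-c2nc(Nc3ccccc3)c3cc(F)ccc3n2)c1` arises from compound 2 by fluoro in place of hydrogen on an aromatic carbon, in words fluoro in place of hydrogen on an aromatic carbon. Since compound 2 stands at the limit of > 50000 nM in this assay, at which 2 of the 2 values shown sit, no step beyond the scatter is expected in this assay, in either direction. Compound 3 is therefore expected near 80000 nM, between 30000 nM and 300000 nM, most likely reported again only as a limit. The expected step that the limit leaves unreadable from compound 2 to compound 3 amounts to nothing beyond the scatter.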

Compound 3, half-maximal inhibitory concentration: 48300 nM
Estimate against measurement, compound 3: 1.7-fold (0.22 log units) above, and the stated range covers the measured number.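

Among these compounds, with fluoro in both places, compound 3 is the first compound here to give a number rather than a limit in this assay, and the change reads as an at least 1.0-fold lower number from compound 2 to compound 3 (0.01 log units; that floor lies within the scatter) and as an at least 1.0-fold lower number from compound 1 to compound 3 (0.01 log units; that floor lies within the scatter). Neither floor goes beyond the scatter, so the true size of either step stays hidden. Compound 1 and compound 2 each give only a limit of the assay: the limit of > 50000 nM in this assay, at which 2 of the 3 values shown sit. From the compounds shown here alone, what remains open is whether chloro, methoxy or an amine on the same aromatic carbon would give a number clearly lower than that of compound 3.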